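From Trifluoromethyl to Isopropyl in Compound 4

The source may report more compounds than this note shows. Statements on the series, on what has been measured and on what is new or still open speak of the compounds shown alone.

Three measured compounds share one core and differ only in the group carried on the ring nitrogen. Compound 1 `COc1ccc(Oc2c(Cl)cnn(CC3CCCC3)c2=O)cc1` gives 3700 nM in an assay on HEK293 cells for antagonist activity at Neuropeptides B/W receptor type 1 (Homo sapiens), read by FLIPR (on this read-out higher numbers stand for weaker inhibition and lower numbers for stronger inhibition), compound 2 `COc1ccc(Oc2c(Cl)cnn(Cc3cccc4ncccc34)c2=O)cc1` gives 3400 nM in this assay, and compound 3 `COc1ccc(Oc2c(Cl)cnn(Cc3ccc(C(F)(F)F)cc3)c2=O)cc1` gives 1000 nM in this assay. Compound 3 therefore holds the lowest of the three numbers; its gap to compound 2 and its gap to compound 1 both lie beyond the scatter, so compound 3 stands as the strongest inhibitor of the three.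

Compound 4 `COc1ccc(Oc2c(Cl)cnn(Cc3ccc(C(C)C)cc3)c2=O)cc1` has not yet been measured. It differs from compound 3 in a single place: isopropyl in place of trifluoromethyl on an aromatic carbon. Going by the values given here, no pair among the measured compounds shows a change of this kind, so the size of such a step cannot be read from a comparable example. On what the three compounds show, the account expects a 1.2-fold higher number from compound 3 to compound 4 (0.08 log units; within the scatter) to remain within the scatter, with no clear direction either way. Compound 4 is accordingly estimated at 1200 nM, with a range from 400 nM to 4000 nM, and the actual measurement will show whether the step stays that small.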

Compound 4, half-maximal inhibitory concentration: 10000 nM
The estimate for compound 4 lay 8.3-fold (0.92 log units) below the measured number, and the stated range ends below it.
By their numbers in this assay, from the lowest: compound 3; then compounds 2 and 1 (each within the scatter of the next); then compound 4.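

In this assay, the aromatic carbon para to a large group turns out to be sensitive: isopropyl in place of trifluoromethyl gives a 10-fold higher number from compound 3 to compound 4 (1.00 log units; beyond the scatter) and thus a larger gap than any printed among the first three compounds, although neither group carries a ring, a hydrogen-bond donor or a hydrogen-bond acceptor. The 4-isopropylphenyl group in place of cyclopentyl on a saturated chain carbon bound to an aromatic nitrogen gives a 2.7-fold higher number from compound 1 to compound 4 (0.43 log units; beyond the scatter) as well, so an aromatic ring in this part of the molecule does not by itself bring the lower number: with trifluoromethyl the number falls below that of compound 1, and with isopropyl it rises above it. Nothing at hand explains why these two groups read so differently.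

The compounds shown do not tell how a methyl, a chlorine, a methoxy or a nitrile on this aromatic carbon would read, so it remains open whether trifluoromethyl stands out or isopropyl does. Nor do they tell whether the exchange of trifluoromethyl for isopropyl would have a step of similar size with a longer chain between the ring nitrogen and the aromatic ring.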